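Notes on chain length and ring size in one series

The compounds below may be only part of what the source reports. "The series", "measured", "known", "first", "only" and "open" are said of these compounds alone.

Compound 2 `CCCCCCCCCCOP(=O)(O)OCCSC(=S)N1CCCC1` carries a decyl chain and the pyrrolidin-1-yl group; in a functional assay on PC-3 cells (Homo sapiens) for inhibition, read by MTT assay, with stated times of 18 h and 4 h (a lower number here means a stronger inhibitor, a higher number a weaker inhibitor), compound 2 gives 56100 nM. Compound 1 `CCCCCCCCOP(=O)(O)OCCSC(=S)N1CCCC1` differs from it by hydrogen in place of ethyl on a saturated chain carbon, eight bonds along the chain from an oxygen on an unsaturated carbon. In this assay compound 1 gives only a limit, > 100000 nM, as recorded in the limit of > 100000 nM in this assay, at which 1 of the 3 values shown sits. Taking off the ethyl thus reads as an at least 1.7-fold higher number from compound 2 to compound 1 (0.25 log units; that floor lies within the scatter). Compound 3 `CCCCCCCCOP(=O)(O)OCCSC(=S)N1CCCCCC1` keeps the chain of compound 1 and carries azepan-1-yl in place of pyrrolidin-1-yl on a thiocarbonyl carbon; in this assay compound 3 gives 56800 nM, which reads as an at least 1.7-fold lower number from compound 1 to compound 3 (0.24 log units; that floor lies within the scatter). Compound 2 and compound 3 are built from the same atoms joined differently; the difference between the two cores is not broken down here, and their values in this assay sit within the scatter of each other.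

Compound 4 `CCCCCCOP(=O)(O)OCCSC(=S)N1CCCCCC1` has not been measured. It differs from compound 3 by hydrogen in place of ethyl on a saturated chain carbon, six bonds along the chain from an oxygen on an unsaturated carbon. For the measured compounds named here, this is the same kind of change as the one from compound 2 to compound 1, not the same change: there the place was eight bonds along the chain from an oxygen on an unsaturated carbon, here it is six bonds along the chain. Because an at least 1.7-fold higher number from compound 2 to compound 1 (0.25 log units; that floor lies within the scatter) ran toward the limit when the ethyl was removed, compound 4 is expected to shift the same way, with a 2.6-fold higher number from compound 3 to compound 4 (0.42 log units; beyond the scatter). In this assay compound 4 is estimated at 150000 nM, probably between 70000 nM and 400000 nM, with a real chance that only a limit is returned.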

Compound 4, half-maximal inhibitory concentration: > 100000 nM
Compound 4: only a limit was reported; the forecaster's own chance of this, stated with the estimate: 60%; the middle value is on the limit's open side.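

In this assay compound 4 is recorded only as a limit, > 100000 nM. Hydrogen in place of ethyl on the azepan-1-yl core reads as an at least 1.7-fold higher number from compound 3 to compound 4 (0.24 log units; that floor lies within the scatter), and set beside the same kind of change on the pyrrolidin-1-yl core, at eight rather than six bonds along the chain from an oxygen on an unsaturated carbon, it gives no sign of a reversal, though neither step is more than a floor within the scatter: the same change on two cores in this assay, an at least 1.7-fold higher number (0.25 log units; that floor lies within the scatter) from compound 2 to compound 1 and an at least 1.7-fold higher number (0.24 log units; that floor lies within the scatter) from compound 3 to compound 4; the limit leaves it open whether they differ What this does not show is a size for the change on either core, or any difference between the two cores, so carrying the change across remains consistent with the data but unproven, and much of the series rests on limits rather than numbers: the limit of > 100000 nM in this assay, at which 2 of the 4 values shown sit.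

Open, from the compounds shown here alone, is whether a longer chain, such as dodecyl, would give numbers on both cores that allow the change to be sized, and whether a decyl chain on the azepan-1-yl core would do the same. Also open, going by these compounds, is whether piperidin-1-yl on the thiocarbonyl carbon would read like pyrrolidin-1-yl or like azepan-1-yl.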